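A few compounds are considered here, and "the series" means these few. Any claim that something is new, unique, unknown or untested is made for them only; others in the source may bear on it.

Measured so far in a functional assay on BGC-823 cells (Homo sapiens) for inhibition, read by MTT assay, with a stated time of 72 h; a lower number here means a stronger inhibitor, a higher number a weaker inhibitor

- compound 1 `O=C1Nc2ccccc2/C1=C\C(=O)c1cccc(Cl)c1` gives 7700 nM
- compound 2 `CC(=O)Nc1cccc(C(=O)/C=C2/C(=O)Nc3ccccc32)c1` gives 9100 nM
- compound 3 `Nc1cccc(C(=O)/C=C2/C(=O)Nc3ccccc32)c1` gives 29900 nM

Compound 3 stands highest of the three at 29900 nM and is the weakest of them. The next compound is compound 4 `C=CC(=O)Nc1cccc(C(=O)/C=C2/C(=O)Nc3ccccc32)c1`, and the change is vinylcarbonyl in place of hydrogen on a nitrogen on an aromatic ring which turns amino into (vinylcarbonyl)amino.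

The closest measured change on this nitrogen is a 3.3-fold higher number from compound 2 to compound 3 (0.52 log units; beyond the scatter) where hydrogen replaces acetyl, a modest step. Read in reverse, it links an acyl group on the nitrogen with the lower number. The other steps give context: a 1.2-fold higher number from compound 1 to compound 2 (0.07 log units; within the scatter) stays level, while a 3.9-fold higher number from compound 1 to compound 3 (0.59 log units; beyond the scatter) is also modest. Going by the values given here, only one acylated example exists, and no measured compound carries vinylcarbonyl, so the transfer from acetyl is uncertain.

A modest step towards a lower number in this assay is therefore expected, which would bring compound 4 close to the level of the acetamido compound. The estimated change is a 3.7-fold lower number from compound 3 to compound 4 (0.57 log units; beyond the scatter) and remains an expectation until measured. Compound 4 is expected near 8000 nM with an estimated range of 2500 nM to 20000 nM in this series.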

Compound 4, half-maximal inhibitory concentration: 3600 nM
Compound 4: middle estimate off by 2.2-fold (0.35 log units), on the high side; measured number inside the range.
By their numbers in this assay, from the lowest: compound 4; then compounds 1 and 2 (each within the scatter of the next); then compound 3.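

In this assay the acylated nitrogen now gives more than one reading: an 8.3-fold lower number from compound 3 to compound 4 (0.92 log units; beyond the scatter) on adding vinylcarbonyl, and with an acyl group present at both ends, vinyl in place of methyl on the carbonyl carbon gives a 2.5-fold lower number from compound 2 to compound 4 (0.40 log units; beyond the scatter) so the result depends on the acyl group and not on acylation alone. Compound 4 also moves past the chloro compound, with a 2.1-fold lower number from compound 1 to compound 4 (0.33 log units; beyond the scatter) whereas the acetamido compound stayed level with it, which makes compound 4 the strongest inhibitor of the four in this assay. No available data account for the difference between vinyl and methyl on this carbonyl carbon.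

Open, going by these compounds, is whether a propanoyl group on the same nitrogen, which has no double bond outside the aromatic rings, would read like compound 2 or like compound 4, and so whether the double bond of vinylcarbonyl matters here. Also open is how a methanesulfonyl group or a longer acyl chain such as butanoyl would read on this nitrogen, since the acyl series shown rests on only two groups.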